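The source may hold more compounds than are shown below. What is called first, only, known or untested is meant among the compounds shown, and "the series" means these compounds.

In a functional assay on DU-145 cells (Homo sapiens) for cytotoxicity, read by MTT assay, with a stated time of 48 h (a lower number here means a stronger inhibitor, a higher number a weaker inhibitor), three compounds have been measured. Compound 1 `CC1(C)CCCC2=CC=C(C=O)CC[C@]21C` gives 191000 nM and compound 2 `C#CC1=CC[C@]2(CC1)C(=C)CC[C@H]2C(C)C` gives 121000 nM while compound 3 `C=C1CCC[C@]2(C)CCC(c3cn(-c4ccc(C(C)=O)cc4)nn3)=CC[C@@]12C` gives 51700 nM as the lowest of the three numbers, beyond the scatter of both others. Compound 4 `C=C1CCC[C@]2(C)CCC(c3cn(-c4ccccc4C(C)=O)nn3)=CC[C@@]12C` has the same atoms as compound 3 joined differently, with 2-acetylphenyl in place of 4-acetylphenyl on an aromatic nitrogen. Within the data shown here, no measured pair shows what such a move does, so only a small step is expected in this assay with a slight lean towards a higher number, possibly none beyond the scatter. The expected step is a 1.2-fold higher number from compound 3 to compound 4 (0.06 log units; within the scatter) on this estimate. Compound 4 is estimated at 60000 nM with an expected range from 30000 nM to 120000 nM in this measurement.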

Compound 4, half-maximal inhibitory concentration: 48500 nM
Estimate against measurement, compound 4: 1.2-fold (0.09 log units) above; the measured number falls inside the stated range.
By their numbers in this assay, from the lowest: compounds 4 and 3 (each within the scatter of the next); then compounds 2 and 1 (each within the scatter of the next).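

In this assay, among these compounds, exchanging 4-acetylphenyl for 2-acetylphenyl on the aromatic nitrogen gives a 1.1-fold lower number from compound 3 to compound 4 (0.03 log units; within the scatter), the first comparison of compounds that differ in one place. At this position, the assay therefore does not separate these two acetylphenyl groups. Nothing measured bears on why they read alike. The compounds shown leave open whether replacing the acetyl group with an amine or a carboxylic acid would shift the number beyond the scatter. They also leave open what a longer chain in place of the phenyl ring would do.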